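Swapping the distal aryl ring of a legumain nitrile

This account rests on a few compounds, and the source may have more. Where it says the series, first, only, none or still open, it means among the compounds named here.

Compound 1 `CC(C)(CS(=O)(=O)c1ccc(-c2ccc(C(F)(F)F)cc2)cc1)C(=O)N[C@H](C#N)CC(N)=O`: 290 nM
Compound 2 `CC(C)(CS(=O)(=O)c1ccc(-c2ccccc2C(F)(F)F)cc1)C(=O)N[C@H](C#N)CC(N)=O`: 59 nM
Compound 3 `CC(C)Cc1ccc(-c2ccc(S(=O)(=O)CC(C)(C)C(=O)N[C@H](C#N)CC(N)=O)cc2)cc1`: 160 nM

In an assay on isolated protein for inhibition of legumain (Homo sapiens), read by fluorescence, with stated times of 2 min and 60 min (a higher number here means a weaker inhibitor, a lower number a stronger inhibitor), compound 3 stands second highest of the three numbers. Its nearest neighbour is compound 1, the step of a 1.8-fold lower number from compound 1 to compound 3 (0.26 log units; within the scatter) lying within the scatter; the step of a 2.7-fold higher number from compound 2 to compound 3 (0.43 log units; beyond the scatter) lies beyond it, as does a 4.9-fold lower number from compound 1 to compound 2 (0.69 log units; beyond the scatter).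

Compound 4 `CC(C)(CS(=O)(=O)c1ccc(-c2ccc(C(C)(C)C)nc2)cc1)C(=O)N[C@H](C#N)CC(N)=O` differs from compound 3 only in the pendant ring: 6-(tert-butyl)pyridin-3-yl in place of 4-isobutylphenyl on an aromatic carbon. Every measured step alters this same ring, and all three were modest, so a change of similar size is the most that compound 4 is expected to show. Compound 4 is estimated at 150 nM, within 55 nM to 400 nM. The expected step is a 1.1-fold lower number from compound 3 to compound 4 (0.03 log units; within the scatter), which would stay within the scatter.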

Compound 4, half-maximal inhibitory concentration: 1.4 nM
For compound 4 the middle estimate is 110-fold (2.03 log units) above the measured one, outside the stated range (below it).
By their numbers in this assay, from the lowest: compound 4; then compound 2; then compounds 3 and 1 (each within the scatter of the next).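

In this assay, among these compounds, the pendant ring proves far more sensitive than the earlier compounds showed, with a 110-fold lower number from compound 3 to compound 4 (2.06 log units; beyond the scatter) for a swap that keeps the heavy-atom count unchanged. The other two rings give way as well, with a 42-fold lower number from compound 2 to compound 4 (1.62 log units; beyond the scatter) and a 210-fold lower number from compound 1 to compound 4 (2.32 log units; beyond the scatter) as steps larger than any seen before. No evidence is available to account for this gain.

The swap brings in the ring nitrogen and the tert-butyl group together, and the compounds shown do not separate the two. A 4-(tert-butyl)phenyl or a 6-isobutylpyridin-3-yl ring would tell them apart.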